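Benzyl fluorine pattern and cytotoxicity on MT4 cells

The compounds below may be only part of what the source reports. "The series", "measured", "known", "first", "only" and "open" are said of these compounds alone.

Measured so far in an ADME assay on MT4 cells (Homo sapiens) for cytotoxicity, read by MTT assay; on this read-out higher numbers stand for lower toxicity in this test and lower numbers for higher toxicity in this test:
- compound 1 `CCOC(=O)/C(O)=C/C(=O)c1cn(Cc2cc(F)cc(F)c2)c2cccc(OC)c12`: 34700 nM
- compound 2 `COc1cccc2c1c(C(=O)/C=C(\O)C(=O)O)cn2Cc1cc(F)cc(F)c1`: 29500 nM
- compound 3 `COc1cccc2c1c(C(=O)/C=C(\O)C(=O)O)cn2Cc1ccc(F)c(F)c1F`: 22800 nM

Compound 1 gives the highest of the three numbers in this assay, but none of the three separates from the others. The nearest is compound 2, a 1.2-fold lower number from compound 1 to compound 2 (0.07 log units; within the scatter). The furthest is compound 3, whose number and that of compound 1 also lie within the scatter of each other.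

Compound 4 `CCOC(=O)/C(O)=C/C(=O)c1cn(Cc2cc(F)ccc2F)c2cccc(OC)c12` has not yet been measured. It differs from compound 1 only in the arrangement of the same atoms: 2,5-difluorophenyl in place of 3,5-difluorophenyl on a saturated chain carbon bound to an aromatic nitrogen.

Going by the values given here, the one measured step that bears on this is the change of the fluorine pattern on the same benzyl position, a 1.3-fold lower number from compound 2 to compound 3 (0.11 log units; within the scatter), which stayed within the scatter. On that basis no step beyond the scatter is expected in this assay for the change from compound 1 to compound 4, in either direction: a 1.1-fold lower number from compound 1 to compound 4 (0.04 log units; within the scatter). Compound 4 is therefore estimated at 32000 nM, with a range from 16000 nM to 65000 nM.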

Compound 4, half-maximal cytotoxic concentration: 41200 nM
Compound 4: middle estimate off by 1.3-fold (0.11 log units), on the low side; low and high end bracket the measured number.
By their numbers in this assay, from the lowest: compounds 3, 2, 1 and 4 (each within the scatter of the next).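

In this assay, the step from 3,5-difluorophenyl to 2,5-difluorophenyl on the saturated chain carbon bound to an aromatic nitrogen, a 1.2-fold higher number from compound 1 to compound 4 (0.07 log units; within the scatter), stays within the scatter. Going by these compounds alone, until now, the only change of fluorine pattern at this place was in compounds 2 and 3, which carry hydrogen in place of the ethyl group; this step shows a second pattern change, now with the ethyl group present, that also does not separate from the scatter. No measured evidence on what lies behind this read-out is available here.

As far as these compounds go, how 2,5-difluorophenyl behaves with hydrogen in place of the ethyl group remains open. From the compounds shown here alone, it is also open whether this place stays within the scatter when it carries something other than a fluorinated phenyl, such as a chlorophenyl, a cyanophenyl or an aminophenyl group.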